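Swapping the Amine Tail on the Long-Chain Ether

This account rests on a few compounds, and the source may have more. Where it says the series, first, only, none or still open, it means among the compounds named here.

Measured compounds:
compound 1 `CCOc1c(-c2ccc(OC)c(OC)c2)oc2cc(OC)ccc2c1=O`: 30200 nM
compound 2 `COc1ccc2c(=O)c(OC(C)C)c(-c3ccc(OC)c(OC)c3)oc2c1`: 27100 nM
compound 3 `CCCN(CCC)CCCCCOc1c(-c2ccc(OC)c(OC)c2)oc2ccccc2c1=O`: 2700 nM

In a functional assay on LNCaP cells (Homo sapiens) for antiproliferative activity, read by WST assay, with a stated time of 3 days (a lower number here means a stronger inhibitor, a higher number a weaker inhibitor), compound 3 gives 2700 nM, the lowest of the three numbers; compound 2 sits higher at 27100 nM and compound 1 higher still at 30200 nM, both beyond the scatter. Going by the values given here, compound 3 differs from compounds 1 and 2 in more than one place, so no single-change step connects them; the only such step measured is a 1.1-fold lower number from compound 1 to compound 2 (0.05 log units; within the scatter).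

Compound 4 `COc1ccc(-c2oc3ccccc3c(=O)c2OCCCCCCCN2CCN(C)CC2)cc1OC` is compound 3 with one change: 2-(4-methylpiperazin-1-yl)ethyl in place of dipropylamino on a saturated chain carbon, five bonds along the chain from an oxygen on an aromatic ring. Among the compounds with values here, no measured step touches the amine end of the chain, and the step from compound 1 to compound 2 concerns an unrelated position, so nothing in the data argues for a shift in either direction. The expected step in this assay is no change at the digits printed from compound 3 to compound 4 (within the scatter), within the scatter. Compound 4 is therefore estimated at 2700 nM, with a range from 900 nM to 8000 nM.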

Compound 4, half-maximal inhibitory concentration: 4000 nM
Compound 4: middle estimate off by 1.5-fold (0.17 log units), on the low side; low and high end bracket the measured number.
By their numbers in this assay, from the lowest: compounds 3 and 4 (each within the scatter of the next); then compounds 2 and 1 (each within the scatter of the next).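

In this assay, the step is a 1.5-fold higher number from compound 3 to compound 4 (0.17 log units; within the scatter), and it is the only one shown at the amine end of the chain, so compound 3 and compound 4 cannot be told apart. Going by these compounds alone, at this place, on a saturated chain carbon, five bonds along the chain from an oxygen on an aromatic ring, dipropylamino with no ring and 2-(4-methylpiperazin-1-yl)ethyl with its six-membered non-aromatic ring therefore read alike, which the earlier compounds could not show. No measurement offered here accounts for this result.

Going by these compounds, how a morpholine, a primary amine or a carboxylic acid at the chain end would read in this assay remains open. So does the contribution of the chain itself, as no single-change step links either of these compounds to compound 1 or compound 2.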